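The source may hold more compounds than are shown below. What is called first, only, known or untested is meant among the compounds shown, and "the series" means these compounds.

Measured in a functional assay on MT4 cells (Homo sapiens) for cytotoxicity; on this read-out higher numbers stand for weaker inhibition and lower numbers for stronger inhibition:
Compound 1 `Cc1ccccc1Sc1cccc(N)c1C#N`: > 40000 nM, a limit
Compound 2 `COc1cccc([S+]([O-])c2cccc(N)c2C#N)c1`: > 80000 nM, a limit
Compound 3 `Cc1cccc([S+]([O-])c2cccc(N)c2C#N)c1`: > 200000 nM, a limit

None of the three compounds has a numerical value. Compound 3 stands only at a limit, > 200000 nM. Compound 4 `N#Cc1cccc([S+]([O-])c2cccc(N)c2C#N)c1` carries cyano in place of methyl on an aromatic carbon, meta to a large group: cyano in place of methyl on an aromatic carbon. Among the measured compounds shown here, the one measured step that bears on this change is a step that the two limits leave unreadable from compound 2 to compound 3, so it offers neither a size nor a direction. No step beyond the scatter is therefore expected in this assay. The expected step, an at least 1.3-fold lower number from compound 3 to compound 4 (0.12 log units; that floor lies within the scatter), is an estimate resting on limits alone. For compound 4 the estimated value is 150000 nM, with an expected range of 50000 nM to 300000 nM.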

Compound 4, half-maximal inhibitory concentration: > 200000 nM
Compound 4 was reported as a limit; the forecaster's own chance of this, stated with the estimate: 80%; at least 1.3-fold (0.12 log units) between middle value and limit.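

In this assay, among the compounds shown here, compound 4 stands only at a limit, as do compound 2 and compound 3, so no step from either of them to compound 4 can be read. Going by these compounds, how cyano compares with methyl or methoxy on this read-out remains open.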